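Dropping an aryl methyl from a benzoxazole anilide

The compounds below may be only part of what the source reports. "The series", "measured", "known", "first", "only" and "open" are said of these compounds alone.

Compound 1 `Cc1ccc2oc(-c3ccc(NC(=O)CN4CCN(CCCN(C)C)CC4)cc3)nc2c1`: 1810 nM
Compound 2 `Cc1cc(-c2nc3cc(F)ccc3o2)ccc1NC(=O)CN1CCN(CCCN(C)C)CC1`: 11800 nM

Both numbers come from a functional assay on C6 cells (Rattus norvegicus) for cytotoxicity, read by MTT assay, with a stated time of 24 h; a lower number here means a stronger inhibitor, a higher number a weaker inhibitor. Of the two, compound 2 stands highest: compound 1 gives the lower number, and the gap between them lies beyond the usual scatter, so compound 2 is the weaker inhibitor of the pair.

Compound 3 `CN(C)CCCN1CCN(CC(=O)Nc2ccc(-c3nc4cc(F)ccc4o3)cc2)CC1` has not yet been measured in this assay. It differs from compound 2 in one place: hydrogen in place of methyl on an aromatic carbon. For the measured compounds named here, no measured pair shows this exact change, so the expectation rests only on the two numbers already in hand. Compound 1, which also carries hydrogen at that place though with a different group on its core, gives 1810 nM, the lower value. A step toward a lower number is expected, a 2.4-fold lower number from compound 2 to compound 3 (0.37 log units; beyond the scatter), of a size that may only just pass the scatter. Compound 3 is therefore estimated at 5000 nM, with a range from 1500 nM to 15000 nM.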

Compound 3, half-maximal inhibitory concentration: 27500 nM
The estimate for compound 3 lay 5.5-fold (0.74 log units) below the measured number; the whole stated range lies below it.
By their numbers in this assay, from the lowest: compound 1; then compound 2; then compound 3.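

In this assay, hydrogen in place of methyl on the aromatic carbon ortho to a large group gives a 2.3-fold higher number from compound 2 to compound 3 (0.37 log units; beyond the scatter). With the 5-fluoro-1,3-benzoxazol-2-yl group present, the compound that keeps this methyl is therefore the stronger inhibitor of the pair, a direction that the first two numbers alone could not reveal. The other single change, fluoro in place of methyl on an aromatic carbon of the core, gives a 15-fold higher number from compound 1 to compound 3 (1.18 log units; beyond the scatter), a large step next to the modest one at the methyl position, and no measurement at hand accounts for either step.

Still open, on these data alone, is whether a methyl on this aromatic carbon would have the same effect on the core of compound 1, which carries no fluoro. An ethyl, methoxy or chloro group on the same carbon would show whether the trend extends beyond methyl.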